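Loss of one trifluoromethyl from compound 1

The source may hold more compounds than are shown below. What is called first, only, known or untested is meant among the compounds shown, and "the series" means these compounds.

Measured so far:
compound 1 `O=C1CCCCC1S(=O)(=O)Nc1cc(C(F)(F)F)ccc1C(F)(F)F` — 68.3%
compound 2 `Cc1cccc(S(=O)(=O)C2CCCCCC2=O)c1C` — 12.1%

In a functional assay on Bel-7402 cells (Homo sapiens) for antiproliferative activity, read by sulforhodamine B assay, tested at 100 ug/mL (a higher number here means more inhibition at the concentration tested (going by the name of the read-out), a lower number less inhibition), compound 1 gives 68.3%, the higher of the two numbers shown. Compound 2 gives 12.1%, a gap beyond the scatter; the two structures differ in several places at once, so their pair says nothing about one change. Compound 3 `O=C1CCCCC1S(=O)(=O)Nc1cccc(C(F)(F)F)c1` differs from compound 1 by hydrogen in place of trifluoromethyl on an aromatic carbon. Among the compounds with values here, no measured step of this kind exists in the set, so the expectation rests on compound 1 alone: a moderate loss of inhibition, larger than the scatter. Compound 3 is expected to give 50%, within 25% to 75%. This estimate means an expected step of a number 18.3 percentage points lower from compound 1 to compound 3 (beyond the scatter).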

Compound 3, a percentage reported as inhibition, at one concentration (the size of the read-out at that concentration, not a potency): 11.4%
For compound 3 the middle estimate is 38.6 percentage points above the measured one, and the stated range ends above it.
By their numbers in this assay, from the lowest: compounds 3 and 2 (each within the scatter of the next); then compound 1.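

In this assay, within the data shown here, hydrogen in place of the trifluoromethyl ortho to a large group gives a number 56.9 percentage points lower from compound 1 to compound 3 (beyond the scatter) as the first single-place step, so the inhibition of compound 1 depends strongly on this one group at this position. The trifluoromethyl kept in compound 3 does not hold that inhibition on its own. Nothing available explains the size of this step.

As far as these compounds go, whether chlorine, methyl or a nitrile at this carbon would hold the inhibition of compound 1 stays open. So does the result of removing only the other trifluoromethyl.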